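The compounds below may be only part of what the source reports. "The series", "measured", "known", "first", "only" and "open" are said of these compounds alone.

Working notes on the series

The series is read in a functional assay on HT-29 cells (Homo sapiens) for cytotoxicity, read by MTT assay, with a stated time of 72 h; on this read-out higher numbers stand for weaker inhibition of growth and lower numbers for stronger inhibition of growth. Compound 1 `C[Se]/C(=N\C(=O)c1cc2ccccc2s1)NC(=O)c1cc2ccccc2s1` carries a methyl on the selenium and two benzothiophene-type amide arms; in this assay compound 1 gives only a limit of the assay, > 100000 nM. Compound 3 `O=C(/N=C(/NC(=O)c1cc2ccccc2s1)[Se]Cc1ccccc1)c1cc2ccccc2s1` is its benzyl counterpart; in this assay compound 3 likewise gives only a limit, > 100000 nM. The change between them is hydrogen in place of phenyl on a saturated chain carbon bound to a selenium atom, and because both ends sit at the limit described in the limit of > 100000 nM in this assay, at which 3 of the 3 values shown sit, the step that the two limits leave unreadable from compound 3 to compound 1 cannot be sized.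

Compound 2 `O=C(/N=C(/NC(=O)c1csc([N+](=O)[O-])c1)[Se]Cc1ccccc1)c1csc([N+](=O)[O-])c1` keeps the benzyl on the selenium but has a different core; the difference between the cores of compound 2 and compound 3 is not broken down here. In this assay compound 2 gives only a limit, > 100000 nM.

Compound 4 `C[Se]/C(=N\C(=O)c1csc([N+](=O)[O-])c1)NC(=O)c1csc([N+](=O)[O-])c1` has not yet been measured. It differs from compound 2 by hydrogen in place of phenyl on a saturated chain carbon bound to a selenium atom, the same change as that from compound 3 to compound 1, made at the same place. Within the data shown here, since the one measured instance of this change, a step that the two limits leave unreadable from compound 3 to compound 1, starts and ends at the limit noted in the limit of > 100000 nM in this assay, at which 3 of the 3 values shown sit, and compound 2 already sits at the limit > 100000 nM, the step from compound 2 to compound 4 is expected to be about a number no higher from compound 2 to compound 4 (the limit leaves the size open), with a strong chance that only a limit is again reported. Compound 4 is therefore expected to fall near 100000 nM, between 30000 nM and 300000 nM.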

Compound 4, concentration for total growth inhibition: > 100000 nM
Compound 4 was reported as a limit; the forecaster's own chance of this, stated with the estimate: 85%; the middle value lies on the limit itself.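

In this assay compound 4 gives > 100000 nM as a limit of the assay and not a number. Among these compounds, the step from compound 2 to compound 4 cannot be read, and no new step comes out of this result: the limit of > 100000 nM in this assay, at which 4 of the 4 values shown sit.

Left open is whether benzyl to methyl changes growth inhibition at all in this assay and whether any of these four compounds has a readable value there.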